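The source may hold more compounds than are shown below. What is called first, only, known or untested is meant among the compounds shown, and "the series" means these compounds.

Measured in an ADME assay on HEK293 cells (Homo sapiens) for cytotoxicity, with a stated time of 6 h; on this read-out higher numbers stand for lower toxicity in this test and lower numbers for higher toxicity in this test:
Compound 1 `CCCCNc1nc(N)nc2cc(OC)ccc12`: > 18000 nM (a limit)
Compound 2 `CCCCNc1nc(N)nc2cc(CO)ccc12`: > 18000 nM (a limit)

Compound 2 stands at > 18000 nM, which is a limit of the assay and not a number. Both measured compounds sit at this point (the limit of > 18000 nM in this assay, at which 2 of the 2 values shown sit). Going by the values given here, the only measured step, a step that the two limits leave unreadable from compound 1 to compound 2, gives no size to build on. Compound 3 `CCCCNc1nc(N)nc2cc(C(N)=O)ccc12` differs from compound 2 as follows: carbamoyl in place of hydroxymethyl on an aromatic carbon. With no readable step to go on, no change beyond the scatter is expected in this assay, and the expected step is a step that the limit leaves unreadable from compound 2 to compound 3. For compound 3 the estimated value is 25000 nM, with an expected range of 12000 nM to 50000 nM.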

Compound 3, half-maximal cytotoxic concentration: > 18000 nM
Compound 3: only a limit was reported; the forecaster's own chance of this, stated with the estimate: 85%; the middle value is on the limit's open side.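

No step among compound 1, compound 2 and compound 3 can be read, because all three values are limits of the assay and not numbers: the limit of > 18000 nM in this assay, at which 3 of the 3 values shown sit.

The compounds shown leave open whether methoxy, hydroxymethyl and carbamoyl differ at all in their effect on the half-maximal cytotoxic concentration.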